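Dimethoxymethyl to diethoxymethyl at the assay limit

The source may hold more compounds than are shown below. What is called first, only, known or untested is meant among the compounds shown, and "the series" means these compounds.

Compound 1 `CC(=O)OC[C@H]1OC(n2cc(C=O)c(=O)[nH]c2=O)C[C@@H]1OC(C)=O`: > 300000 nM (a limit)
Compound 2 `COC(OC)c1cn(C2C[C@H](OC(C)=O)[C@@H](COC(C)=O)O2)c(=O)[nH]c1=O`: > 300000 nM (a limit)
Compound 3 `COC(OC)c1cn(C2C[C@H](O)[C@@H](CO)O2)c(=O)[nH]c1=O`: > 300000 nM (a limit)

All three compounds were tested in a functional assay on HFF cells (Homo sapiens) for cytotoxicity, read by neutral red uptake; on this read-out lower numbers stand for higher toxicity in this test and higher numbers for lower toxicity in this test. Compound 3 gives > 300000 nM, which is a limit of the assay and not a number. The whole set looks the same: the limit of > 300000 nM in this assay, at which 3 of the 3 values shown sit.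

Compound 4 `CCOC(OCC)c1cn(C2C[C@H](O)[C@@H](CO)O2)c(=O)[nH]c1=O` keeps the shared core of compound 3 and changes one group: diethoxymethyl in place of dimethoxymethyl on an aromatic carbon. In words, this is diethoxymethyl in place of dimethoxymethyl on an aromatic carbon.

Among the measured compounds shown here, only one measured step touches this place: a step that the two limits leave unreadable from compound 1 to compound 2. Both of its ends are limits, so it offers no size to carry over to the new change.

The expectation therefore rests on compound 3, with its limit of > 300000 nM. No step beyond the scatter is expected in this assay, and compound 4 will most likely read as a limit again. The step expected is a number no higher from compound 3 to compound 4 (the limit leaves the size open). For compound 4 the estimate is 300000 nM, with an expected range of 150000 nM to 500000 nM.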

Compound 4, half-maximal cytotoxic concentration: > 300000 nM
Compound 4: only a limit was reported (the forecaster's own chance of this, stated with the estimate: 85%); the middle value lies on the limit itself.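

In this assay compound 4 gives > 300000 nM, which is a limit and not a number. Compound 3 also reads as a limit, so no step can be read between compound 3 and compound 4. Whether diethoxymethyl and dimethoxymethyl differ at all on this read-out stays open, because every compound shown reads the same: the limit of > 300000 nM in this assay, at which 4 of the 4 values shown sit.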